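From Acetyl to Benzoyl: Compound 2 to Compound 3

This account rests on a few compounds, and the source may have more. Where it says the series, first, only, none or still open, it means among the compounds named here.

Compound 2 `CC(=O)N1CCN(C(=O)C[C@H](Cc2ccc(Cl)cc2)C(=O)N2CCN(c3ccccc3N(CC3CC3)S(C)(=O)=O)CC2)CC1` was examined in a functional assay with Melanocortin receptor 4 (Homo sapiens) as the target, read by cAMP accumulation; on this read-out higher numbers stand for an effect only at larger amounts of compound and lower numbers for an effect already at smaller amounts. In this assay compound 2 gives only a limit, > 10000 nM. Its nearest measured relative is compound 1 `CCN1CCN(C(=O)C[C@H](Cc2ccc(Cl)cc2)C(=O)N2CCN(c3ccccc3N(CC3CC3)S(C)(=O)=O)CC2)CC1`, which carries ethyl where compound 2 carries acetyl. In this assay compound 1 likewise gives only a limit, > 10000 nM. Going by the values given here, the single measured step, a step that the two limits leave unreadable from compound 1 to compound 2, therefore shows neither size nor direction, since both values sit at the limit of > 10000 nM in this assay, at which 2 of the 2 values shown sit.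

Compound 3 `CS(=O)(=O)N(CC1CC1)c1ccccc1N1CCN(C(=O)[C@H](CC(=O)N2CCN(C(=O)c3ccccc3)CC2)Cc2ccc(Cl)cc2)CC1` differs from compound 2 by phenyl in place of methyl on a carbonyl carbon whose other neighbours are an amide-type nitrogen in a ring; cut one bond further out, the same difference reads acetyl to benzoyl. Among the compounds with values here, no measured step bears on this change, and the one step available is unreadable because the limit of > 10000 nM in this assay, at which 2 of the 2 values shown sit, holds both of its ends.

With compound 2 at a limit, the step that the limit leaves unreadable from compound 2 to compound 3 is expected to be small and of no readable direction. Compound 3 is accordingly estimated at about 15000 nM, within 3000 nM to 60000 nM, and this assay is expected, more likely than not, to report only a limit once more.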

Compound 3, half-maximal effective concentration: 83 nM
Estimate against measurement, compound 3: 180-fold (2.26 log units) above, outside the stated range (below it).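

The earlier pair gave no readable step at this position, but in this assay the change to phenyl in place of methyl on a carbonyl carbon brings an at least 120-fold lower number from compound 2 to compound 3 (2.08 log units; beyond the scatter). Set against ethyl at this place, benzoyl brings an at least 120-fold lower number from compound 1 to compound 3 (2.08 log units; beyond the scatter), so the group at this one place separates a measurable value from the limit reached with both ethyl and acetyl. Each step is known from one side only, because compound 1 and compound 2 stay at a limit: the limit of > 10000 nM in this assay, at which 2 of the 3 values shown sit.

What the compounds shown leave open is which part of the benzoyl group carries the step: a benzyl group on the same ring nitrogen would test the phenyl without its carbonyl, and a cyclohexyl group on the carbonyl carbon would test whether the ring needs to be aromatic. They also leave open how the value would respond to other groups on that carbonyl carbon, such as a pyridine ring, a substituted phenyl or a longer chain.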